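The source may report more compounds than this note shows. Statements on the series, on what has been measured and on what is new or still open speak of the compounds shown alone.

Compound 2 `O=S(=O)(Nc1cccc2c1CCCC2c1c[nH]cn1)C1CC1` carries the (cyclopropylsulfonyl)amino group; in an assay on isolated protein (Cricetulus griseus) for binding affinity to Alpha-1B adrenergic receptor (Mesocricetus auratus), read by radioligand binding (a higher number here means a weaker inhibitor, a lower number a stronger inhibitor), compound 2 gives < 10000 nM, which is a limit of the assay. Compound 1 `CN(c1cccc2c1CCCC2c1c[nH]cn1)S(C)(=O)=O` differs only at that position, and in this assay compound 1 gives < 10000 nM, likewise a limit. The step that the two limits leave unreadable from compound 1 to compound 2 is therefore unreadable, as the limit of < 10000 nM in this assay, at which 2 of the 2 values shown sit, records. Compound 3 `CC(=O)Nc1cccc2c1CCCC2c1c[nH]cn1` has yet to be measured; it differs from compound 2 by acetyl in place of cyclopropylsulfonyl on a nitrogen on an aromatic ring. Within the data shown here, no measured step reads on this change, so no direction beyond the scatter can be anticipated. For compound 3 the estimate in this assay is 800 nM (range 40 nM to 9000 nM). The step that the limit leaves unreadable from compound 2 to compound 3 is accordingly expected to be small.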

Compound 3, inhibition constant: < 10000 nM
Compound 3: no number, only a limit; the forecaster's own chance of this, stated with the estimate: 60%; the middle value does not contradict the limit.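

No new step can be read among compound 1, compound 2 and compound 3 in this assay, because all of them rest on one value: the limit of < 10000 nM in this assay, at which 3 of the 3 values shown sit. As far as these compounds go, the actual affinity of each compound and the size of every step between them remain open.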